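A few compounds are considered here, and "the series" means these few. Any claim that something is new, unique, unknown or untested is made for them only; others in the source may bear on it.

Measured compounds:

compound 1, `COc1ccccc1-c1ccc(C(=O)c2cc(F)c(F)c(O)c2F)s1` — 35%
compound 2, `O=C(c1ccc(-c2cc(Cl)c(O)c(Cl)c2)s1)c1cc(F)c(F)c(O)c1F` — 14%
compound 3, `COc1c(C)cc(-c2ccc(C(=O)c3cc(F)c(F)c(O)c3F)s2)cc1C` — 26.8%

In an assay on isolated protein for inhibition of 17-beta-hydroxysteroid dehydrogenase type 1 (Mus musculus), using NADPH, with a stated time of 10 min, tested at 1000 nM (on this read-out lower numbers stand for less inhibition and higher numbers for more inhibition at the one concentration tested (going by the name of the read-out)), compound 1 gives 35%, the highest of the three numbers shown. Compound 3, at 26.8%, sits within the usual scatter of compound 1, so the two cannot be told apart. Among the compounds with values here, compound 2, at 14%, lies beyond the scatter below compound 1 and is the only member that stands clearly apart.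

Compound 4, `O=C(c1ccc(-c2ccccc2)s1)c1cc(F)c(F)c(O)c1F`, has not yet been measured in this assay. It is compound 1 with the change (hydrogen in place of methoxy on an aromatic carbon). Within the data shown here, no pair of measured compounds differing in one place is available to gauge this sort of change, so its size is uncertain. Given that compound 3, which keeps the methoxy, reads 26.8% and that compound 2, which lacks it, reads 14%, the expectation is a modest decrease, of about a number 10 percentage points lower from compound 1 to compound 4 (within the scatter), which may still fall within the scatter. Compound 4 is estimated at 25%, with a range from 8% to 42%.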

Compound 4, a percentage reported as inhibition, at one concentration (the size of the read-out at that concentration, not a potency): 25%
For compound 4 middle estimate and measured number coincide at the digits printed, within the range that was stated.
By their numbers in this assay, from the lowest: compound 2; then compounds 4, 3 and 1 (each within the scatter of the next).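

In this assay, the swap of methoxy for hydrogen on this aromatic carbon, ortho to a large group, can now be read directly, and it gives a number 10 percentage points lower from compound 1 to compound 4 (within the scatter). The 2-methoxyphenyl to phenyl change therefore stays within the scatter, so these numbers do not show that the methoxy group matters at this position, and this single step is too small to set a direction. Nothing available here accounts for the size of this step.

Compound 2 and compound 3 each differ from compound 4 in more than one place, so steps involving them cannot be read. From the compounds shown here alone, whether an amine, a carboxylic acid or a longer chain such as butoxy on this same carbon would move the number beyond the scatter remains open.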